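The compounds below may be only part of what the source reports. "The series", "measured", "known", "first", "only" and "open" are said of these compounds alone.

Measured compounds:
- compound 1 `c1ccc(Sc2ncnc3[nH]cnc23)cc1` gives 0%
- compound 2 `Fc1ccc(Sc2ncnc3[nH]cnc23)cc1` gives 0%
- compound 3 `COc1ncnc2ncn(Cc3ccc(F)cc3)c12` gives 0%

For the measured compounds named here, in an assay on isolated protein for inhibition of RAC-alpha serine/threonine-protein kinase (Homo sapiens), tested at 30 uM (on this read-out higher numbers stand for more inhibition at the one concentration tested (going by the name of the read-out) and lower numbers for less inhibition), compound 2 stands level with compound 1 and compound 3; its nearest neighbour is compound 1, and the measured step of no change at the digits printed from compound 1 to compound 2 (within the scatter) is the only single-point change recorded so far. That step bears only indirectly on the change now considered, which is benzyl in place of hydrogen on an aromatic nitrogen, leading to compound 4 `Fc1ccc(Sc2ncnc3c2ncn3Cc2ccccc2)cc1`. Going by the values given here, no measured pair shows a benzyl group entering on a ring nitrogen of this core; compound 3, which carries a substituted benzyl on a ring nitrogen, gives 0% in this assay, but it differs from compound 2 in more than one place, so no step is drawn. Among the compounds with values here, with all three measured compounds at the same level and the one recorded step showing no change, no movement beyond the scatter is expected. Compound 4 is therefore estimated at 3%, between 0% and 20%. This estimate means an expected step of a number 3 percentage points higher from compound 2 to compound 4 (within the scatter).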

Compound 4, a percentage reported as inhibition, at one concentration (the size of the read-out at that concentration, not a potency): 1%
Compound 4: the middle estimate sits 2 percentage points above what was measured; the range from low to high includes it.
By their numbers in this assay, from the lowest: compounds 1, 2, 3 and 4 (each within the scatter of the next).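

For the compounds shown here, compound 4 gives the first direct pair for a benzyl group on an aromatic nitrogen of the shared core: in this assay the change amounts to a number 1 percentage points higher from compound 2 to compound 4 (within the scatter) and so does not separate the benzyl from the hydrogen it replaces. Compound 2 starts at 0% on this read-out, so the pair shows that this benzyl does not lift the number beyond the scatter, but it cannot show any loss. No measurement available here offers an explanation for this result. On these data alone, whether another group on this aromatic nitrogen, such as an aminoethyl chain or a carboxylic acid on a longer chain, would raise the read-out remains open. So does whether any change at this position matters when the rest of compound 4 is altered as well.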